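Swapping a Chain End for an Alkyne

The source may hold more compounds than are shown below. What is called first, only, known or untested is meant among the compounds shown, and "the series" means these compounds.

Three measured compounds share one core and differ only in the chain attached to the aromatic nitrogen. Compound 1 `CCC(CC)Cn1c(Cc2cc(OC)c(OC)c(OC)c2)nc2c(N)ncnc21` gives 158000 nM in a functional assay on MCF7 cells (Homo sapiens) for antiproliferative activity; on this read-out higher numbers stand for weaker inhibition and lower numbers for stronger inhibition. Compound 2 `COc1cc(Cc2nc3c(N)ncnc3n2CCOC(C)C)cc(OC)c1OC` gives 38900 nM in this assay. Compound 3 `CCCCCn1c(Cc2cc(OC)c(OC)c(OC)c2)nc2c(N)ncnc21` gives 61700 nM in this assay, the second highest of the three numbers: the step of a 2.6-fold lower number from compound 1 to compound 3 (0.41 log units; beyond the scatter) lies beyond the scatter, whereas compound 2 and compound 3 sit within the scatter of each other.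

Compound 4 `C#CCCCn1c(Cc2cc(OC)c(OC)c(OC)c2)nc2c(N)ncnc21` differs from compound 3 by ethynyl in place of ethyl on a saturated chain carbon, three bonds along the chain from an aromatic nitrogen. For the measured compounds named here, no measured step alters the far end of the chain in this way. Going by the values given here, the two steps of a 4.1-fold lower number from compound 1 to compound 2 (0.61 log units; beyond the scatter) and a 2.6-fold lower number from compound 1 to compound 3 (0.41 log units; beyond the scatter) reshape the chain where it meets the nitrogen and are modest in size, while the one step made further along the chain, a 1.6-fold higher number from compound 2 to compound 3 (0.20 log units; within the scatter), stays within the scatter. On that basis the step from compound 3 to compound 4 is expected to be small, a 1.0-fold lower number from compound 3 to compound 4 (0.01 log units; within the scatter), with no clear direction. Compound 4 is therefore estimated at 60000 nM, with a range from 20000 nM to 180000 nM.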

Compound 4, half-maximal inhibitory concentration: 24000 nM
Compound 4: middle estimate off by 2.5-fold (0.40 log units), on the high side; the range from low to high includes it.
By their numbers in this assay, from the lowest: compounds 4, 2 and 3 (each within the scatter of the next, the first and the last beyond it); then compound 1.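

With a 2.6-fold lower number from compound 3 to compound 4 (0.41 log units; beyond the scatter) as the result, the far end of the chain is shown to matter in this assay even though ethynyl and ethyl have the same count of heavy atoms, and the triple bond is the one new feature counted in the change. The pent-4-yn-1-yl chain of compound 4 cannot be told apart from the isopropoxy-bearing chain of compound 2, as a 1.6-fold lower number from compound 2 to compound 4 (0.21 log units; within the scatter) shows, while a 6.6-fold lower number from compound 1 to compound 4 (0.82 log units; beyond the scatter) is the widest step among these compounds. The data shown offer no measurement that explains why the alkyne shifts the number.

Going by these compounds, whether a chain ending in a double bond would shift the number in the same way stays open. So does the outcome for a longer chain ending in the same alkyne, or for a chain ending in a nitrile or an amine.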